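This account rests on a few compounds, and the source may have more. Where it says the series, first, only, none or still open, it means among the compounds named here.

Measured compounds:
- compound 1, `CN1CCN(CCCCCn2c3c(c4ccccc42)C(=O)c2c[n+]([O-])c4ccccc4c2C3=O)CC1`: 1710 nM
- compound 2, `O=C1c2c[n+]([O-])c3ccccc3c2C(=O)c2c1c1ccccc1n2Cc1cn([C@H]2C[C@H](O)[C@@H](CO)O2)nn1`: 390 nM
- compound 3, `O=C1c2c[n+]([O-])c3ccccc3c2C(=O)c2c1c1ccccc1n2Cc1cn([C@@H]2C[C@H](O)[C@@H](CO)O2)nn1`: 20 nM

In a functional assay on A-375 cells (Homo sapiens) for cytotoxicity, read by MTT assay, with a stated time of 72 h (on this read-out lower numbers stand for stronger inhibition and higher numbers for weaker inhibition), compound 1 gives 1710 nM, the highest of the three numbers shown. Its nearest neighbour is compound 2, and the gap to compound 3 is wider still. For the measured compounds named here, the only step between compounds that differ in one place is a 20-fold lower number from compound 2 to compound 3 (1.29 log units; beyond the scatter), and it rests on the fact that compounds 2 and 3 differ only in the configuration as drawn alone, a change in configuration at a saturated ring carbon.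

Compound 4, `O=C1c2c[n+]([O-])c3ccccc3c2C(=O)c2c1c1ccccc1n2CCCCN1CCCCC1`, is not yet measured. It differs from compound 1 by piperidin-1-yl in place of (4-methylpiperazin-1-yl)methyl on a saturated chain carbon, four bonds along the chain from an aromatic nitrogen. No measured step concerns a change of this kind: the one step shown is a change of configuration, not of a chain end, so it gives no guide to the size or direction of the move from compound 1 to compound 4. The account therefore expects no step beyond the scatter, a 1.0-fold lower number from compound 1 to compound 4 (0.00 log units; within the scatter). The estimate for compound 4 in this assay is 1700 nM, within a range from 500 nM to 6000 nM.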

Compound 4, half-maximal inhibitory concentration: 190 nM
Estimate against measurement, compound 4: 8.9-fold (0.95 log units) above; the whole stated range lies above it.
By their numbers in this assay, from the lowest: compound 3; then compound 4; then compound 2; then compound 1.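

In this assay, the end of the chain on the shared core proves to be a place where the number can move: the change to piperidin-1-yl gives a 9.0-fold lower number from compound 1 to compound 4 (0.95 log units; beyond the scatter). Until now, the only step shown was a change of configuration, and this is the first to show an effect from changing the group itself. The same difference also reads as 4-(4-methylpiperazin-1-yl)butyl to 3-(piperidin-1-yl)propyl, so the ring and the length of the chain change together, and nothing shown gives a reason for the step.

The compounds shown leave open how much of the step belongs to the ring and how much to the chain. They also leave open how a morpholine ring or a dimethylamino group would read at the end of the chain.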